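The compounds below may be only part of what the source reports. "The series", "measured", "known", "first", "only" and "open" are said of these compounds alone.

Compound 1 `O=C(Nc1cc(-c2ccccc2)[nH]n1)c1ccc(Br)nc1`: 8870 nM
Compound 2 `O=C(Nc1cc(-c2ccc(Br)cc2)[nH]n1)c1cccnc1F`: 5420 nM

Both values come from a functional assay on A-375 cells (Homo sapiens) for antiproliferative activity, read by MTT assay, with a stated time of 48 h; a lower number here means a stronger inhibitor, a higher number a weaker inhibitor. There, compound 2 gives 5420 nM, which lies within the usual scatter of the value for compound 1, so the two cannot be ranked. Within the data shown here, the compounds differ in more than one place, so no single-change step has been measured.

Compound 3 `O=C(Nc1cc(-c2ccc(Br)cc2)[nH]n1)c1ccc(Br)nc1` has not yet been measured. It carries 6-bromopyridin-3-yl in place of 2-fluoropyridin-3-yl on a carbonyl carbon. Among the measured compounds shown here, with no measured step as a guide, the expectation rests only on the two close values, and no shift beyond the scatter is expected in either direction. The estimated change is a 1.1-fold lower number from compound 2 to compound 3 (0.04 log units; within the scatter), which is expected to remain within the scatter. In this assay, compound 3 is estimated at 5000 nM, with an expected range from 1800 nM to 14000 nM.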

Compound 3, half-maximal inhibitory concentration: 9910 nM
Estimate against measurement, compound 3: 2.0-fold (0.30 log units) below, within the range that was stated.
By their numbers in this assay, from the lowest: compounds 2, 1 and 3 (each within the scatter of the next).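

In this assay, 6-bromopyridin-3-yl in place of 2-fluoropyridin-3-yl on a carbonyl carbon gives a 1.8-fold higher number from compound 2 to compound 3 (0.26 log units; within the scatter) and so does not separate the two compounds. The first single-change steps also show that bromo in place of hydrogen on an aromatic carbon gives a 1.1-fold higher number from compound 1 to compound 3 (0.05 log units; within the scatter) and likewise separates neither compound, so neither change can be ranked as a gain or a loss in this assay. Nothing shown offers an explanation for either result.

As far as these compounds go, it remains open whether a piperidine ring or a morpholine ring in place of the pyridine ring on the carbonyl carbon would move the number beyond the scatter. From the compounds shown here alone, it is equally open whether a methoxy group or a nitrile in place of the bromo on the aromatic carbon would do so.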